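The compounds below may be only part of what the source reports. "The series", "measured", "known", "first", "only" and "open" are said of these compounds alone.

Measured compounds:
compound 1 `CC(C)CCCc1nc(O)cc(O)n1` — 2110 nM
compound 2 `CCCCCCc1nc(O)cc(O)n1` — 454 nM
compound 3 `CCCCCCCCNc1nc(O)cc(O)n1` — 6.14 nM
Not yet measured: compound 4 `CCCCCCCc1nc(O)cc(O)n1`

In a functional assay on HEK293 cells for agonist activity at G-protein coupled receptor 84 (Homo sapiens), read by calcium flux (a higher number here means that more compound is needed for the effect, a lower number that less compound is needed), compound 2 stands second highest of the three numbers. Going by the values given here, its nearest neighbour is compound 1, and the step of a 4.6-fold lower number from compound 1 to compound 2 (0.67 log units; beyond the scatter) is the only one-place change measured so far. The lowest number belongs to compound 3, whose value 6.14 nM sits far below that of compound 2; compound 3 differs from compound 2 in two places at once, so its gap cannot be assigned to either change alone.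

Compound 4 carries the change (methyl in place of hydrogen on a saturated chain carbon, six bonds along the chain from an aromatic carbon). Among the compounds with values here, no measured step covers exactly this change: the step from compound 1 to compound 2 alters the shape of the same saturated chain without adding a carbon, and the shared core is untouched in both cases. What the numbers do show is that the chain region is sensitive, and that the longer-chained compound 3 gives the lowest number of the set. A modest move to a lower number in this assay is therefore expected, of a size comparable to the measured step, but not a large one.

For compound 4 the estimate is 200 nM, with a range from 60 nM to 700 nM. This amounts to an expected step of a 2.3-fold lower number from compound 2 to compound 4 (0.36 log units; beyond the scatter).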

Compound 4, half-maximal effective concentration: 12.7 nM
Estimate against measurement, compound 4: 16-fold (1.20 log units) above; measured number outside the range, below it.
By their numbers in this assay, from the lowest: compound 3; then compound 4; then compound 2; then compound 1.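

In this assay, methyl in place of hydrogen on a saturated chain carbon, six bonds along the chain from an aromatic carbon, gives a 36-fold lower number from compound 2 to compound 4 (1.55 log units; beyond the scatter) and so counts as a large step. The earlier step of a 4.6-fold lower number from compound 1 to compound 2 (0.67 log units; beyond the scatter) is only modest, so this position responds far more strongly to the addition of one carbon than the earlier change of propyl for isopropyl suggested. With the shared core unchanged, the full span of the chain changes read here is a 170-fold lower number from compound 1 to compound 4 (2.22 log units; beyond the scatter). Nothing available here bears on the reason for these steps, which therefore stand as observations only.

The compounds shown leave open whether a longer chain than that of compound 4 lowers the number further or raises it again. Compound 3 at 6.14 nM differs from compound 4 in more than one place, so the contribution of its amine link remains unresolved, and an octyl chain placed directly on the shared core would separate the two changes.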